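Trimming the Aryl Cap to a Single Bromine

This account rests on a few compounds, and the source may have more. Where it says the series, first, only, none or still open, it means among the compounds named here.

Measured compounds:
compound 1 `O=C(NO)c1ccc(/C=C/c2ccnc(-c3ccccc3O)c2)cc1`: 47 nM
compound 2 `Cc1ccc(-c2cc(/C=C/c3ccc(C(=O)NO)cc3)ccn2)c(F)c1`: 15 nM

Within the data shown here, in an assay on isolated protein for inhibition of protein deacetylase HDAC6 (Homo sapiens), read by fluorescence, with a stated time of 15 min (a higher number here means a weaker inhibitor, a lower number a stronger inhibitor), compound 2 holds the lower of the two numbers; the only measured step, a 3.1-fold lower number from compound 1 to compound 2 (0.50 log units; beyond the scatter), separates it from compound 1. Compound 3 `O=C(NO)c1ccc(/C=C/c2ccnc(Br)c2)cc1` differs from compound 2 by bromo in place of 2-fluoro-4-methylphenyl on an aromatic carbon. Among the measured compounds shown here, no measured step removes the aryl group altogether, so that one step is the only guide, and it shows the group at this place shifting the number only modestly. A weaker inhibitor is expected for compound 3, with a step of a 3.3-fold higher number from compound 2 to compound 3 (0.52 log units; beyond the scatter). The estimate for compound 3 is 50 nM, within 15 nM to 200 nM.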

Compound 3, half-maximal inhibitory concentration: 320 nM
Beside the measured number, compound 3's estimate is 6.4-fold (0.81 log units) below it; measured number outside the range, above it.
By their numbers in this assay, from the lowest: compound 2; then compound 1; then compound 3.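

In this assay, the earlier change between two aryl groups showed only a modest shift, whereas losing the aryl ring at this place, next to the ring nitrogen, costs much more. Bromo in place of 2-fluoro-4-methylphenyl gives the larger step (a 21-fold higher number from compound 2 to compound 3 (1.33 log units; beyond the scatter)), and bromo in place of 2-hydroxyphenyl gives a modest one (a 6.8-fold higher number from compound 1 to compound 3 (0.83 log units; beyond the scatter)). Nothing available explains these losses. The compounds shown leave open whether an unsubstituted phenyl or a small amine at this place would fall nearer compound 2 or compound 3.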